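The compounds below may be only part of what the source reports. "The series", "measured", "known", "first", "only" and "open" are said of these compounds alone.

Among the compounds with values here, compound 1, with the structure `Nc1ccccc1NC(=O)/C=C/c1ccc(CSc2ccc(F)cc2)cc1`, is one of two compounds measured in a functional assay on SMMC-7721 cells (Homo sapiens) for inhibition, read by CCK-8 assay, with a stated time of 72 h, tested at 8 uM; a lower number here means less inhibition of growth, a higher number more inhibition of growth at the concentration tested; in that assay compound 1 gives 15.4%. This is the lower of the two numbers. The other measured compound is compound 2, `COc1ccc(SCc2ccc(C(=O)Nc3ccccc3N)cc2)cc1`, and in this assay compound 2 gives 80.1%, a figure that lies well beyond the scatter above that of compound 1. Within the data shown here, compound 1 and compound 2 differ in more than one place, so no single step between them can be read off; the two values show only that compound 2 inhibits growth far more strongly at the concentration tested.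

The unmeasured compound 3, `Nc1ccccc1NC(=O)/C=C/c1ccc(CSCCc2ccccc2)cc1`, keeps the core of compound 1 and differs from it in one place: phenethyl in place of 4-fluorophenyl on a sulfur. Among the measured compounds shown here, no measured pair shows what this kind of change does on this core. With compound 1 starting so low, the step from compound 1 to compound 3 is expected to be a small rise at most, quite possibly none beyond the scatter, namely a number 9.6 percentage points higher from compound 1 to compound 3 (within the scatter). Compound 3 is therefore estimated at 25%, within a range from 5% to 55%.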

Compound 3, percent growth inhibition at one concentration: 15.8%
For compound 3 the middle estimate is 9.2 percentage points above the measured one; the measured number falls inside the stated range.
By their numbers in this assay, from the lowest: compounds 1 and 3 (each within the scatter of the next); then compound 2.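

Phenethyl in place of 4-fluorophenyl on a sulfur gives a number 0.4 percentage points higher from compound 1 to compound 3 (within the scatter) in this assay and so leaves the reading on the core of compound 1 unchanged within the scatter. Within the data shown here, this is the first step read at this position, and it shows that on this core the change from 4-fluorophenyl to phenethyl, which removes the fluorine and brings 8 heavy atoms in place of 7 while keeping one six-membered aromatic ring of carbon only, does not separate compound 1 from compound 3 in growth inhibition at the concentration tested. Nothing is available from independent measurements that bears on this result.

Because both groups end in the same kind of aromatic ring, the compounds shown leave open whether a group of a different type on the sulfur, such as an amine or a carboxylic acid, would shift the number on this core. As far as these compounds go, it also remains open whether the same exchange would read alike on the core of compound 2, which differs from compound 1 in more than one place.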